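From Methoxy to Chloro: A Small Expected Step

The compounds below may be only part of what the source reports. "The series", "measured", "known", "first", "only" and "open" are said of these compounds alone.

In a functional assay on A549 cells (Homo sapiens) for cytotoxicity, read by MTT assay, with a stated time of 68 h (a higher number here means a weaker inhibitor, a lower number a stronger inhibitor), compound 2 `COc1cccc(-c2cccc(NC(=O)C(Cl)Cl)c2)c1` gives 4310 nM, the lowest number of the three measured compounds, which makes it the strongest inhibitor among them. Compound 1 `O=C(Nc1cccc(-c2cccc(F)c2)c1)C(Cl)Cl` gives 9530 nM, and compound 3 `COc1cccc(-c2cc(NC(=O)C(Cl)Cl)cc(-c3cccc(OC)c3)c2)c1` gives 9400 nM.

Compound 4 `O=C(Nc1cccc(-c2cccc(Cl)c2)c1)C(Cl)Cl` has not yet been measured. It differs from compound 2 in one place, with chloro in place of methoxy on an aromatic carbon. The most useful evidence comes from compound 1, which carries fluoro where compound 4 carries chloro. Its step to the methoxy compound, a 2.2-fold lower number from compound 1 to compound 2 (0.34 log units; beyond the scatter), was modest and involved the same kind of swap in the opposite direction, methoxy in place of fluoro. The other measured step, a 2.2-fold higher number from compound 2 to compound 3 (0.34 log units; beyond the scatter), adds 3-methoxyphenyl in place of hydrogen, so it says little about this change. Among the compounds with values here, no measured compound here carries chloro, so a halogen's effect can be judged only from fluoro. In this assay, the expected result is a small rise in the number, possibly no larger than the usual scatter: a 1.5-fold higher number from compound 2 to compound 4 (0.18 log units; within the scatter). For compound 4 the estimated value is 6500 nM, with an expected range from 3200 nM to 13000 nM.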

Compound 4, half-maximal inhibitory concentration: 21400 nM
Compound 4: the middle estimate sits 3.3-fold (0.52 log units) below what was measured, and the stated range ends below it.
By their numbers in this assay, from the lowest: compound 2; then compounds 3 and 1 (each within the scatter of the next); then compound 4.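

Chloro in place of methoxy at this spot, on an aromatic carbon meta to a large group, gave a 5.0-fold higher number from compound 2 to compound 4 (0.70 log units; beyond the scatter) in this assay, a larger step than any seen among the earlier compounds. The two halogens also behave differently here: chloro in place of fluoro gave a 2.2-fold higher number from compound 1 to compound 4 (0.35 log units; beyond the scatter) and so compound 1 proved a poor stand-in for compound 4, with the numbers rising from methoxy in compound 2, through fluoro in compound 1, to chloro in compound 4. No measurement on these compounds accounts for this rise, so it stands as an observed difference in cell cytotoxicity without an explanation.

As far as these compounds go, only methoxy, fluoro and chloro can be compared at this position on the shared core, so it remains open how a bromo group, a nitrile, an amine or a carboxylic acid would behave there. From the compounds shown here alone, it is also open whether the same order of groups would hold on the core of compound 3, which carries a second 3-methoxyphenyl group.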